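This account rests on a few compounds, and the source may have more. Where it says the series, first, only, none or still open, it means among the compounds named here.

Of the compounds shown here, two on a shared core have been measured in a functional assay on HCT-15 cells (Homo sapiens) for cytotoxicity, in the presence of a further agent that is not named here; a lower number here means a stronger inhibitor, a higher number a weaker inhibitor. Compound 1 `Clc1ccc(-c2cc(-c3cccs3)nc(-c3ccccc3Cl)c2)o1` gives 6190 nM. Compound 2 `Clc1ccc(-c2cc(-c3ccc(Cl)o3)cc(-c3ccsc3)n2)cc1` gives 5190 nM, the lower of the two numbers, though its gap to compound 1 lies within the scatter. Compound 3 `Clc1ccc(-c2cc(-c3ccc(Cl)o3)cc(-c3cccs3)n2)cc1` awaits measurement; it differs from compound 2 by thiophen-2-yl in place of thiophen-3-yl on an aromatic carbon. Within the data shown here, no measured pair isolates this change, so nothing beyond the scatter is expected in this assay, in either direction. For compound 3 the estimate in this assay is 5000 nM, within 2500 nM to 10000 nM. The expected step is a 1.0-fold lower number from compound 2 to compound 3 (0.02 log units; within the scatter).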

Compound 3, half-maximal inhibitory concentration: 14200 nM
Compound 3: the middle estimate sits 2.8-fold (0.45 log units) below what was measured, outside the stated range (above it).
By their numbers in this assay, from the lowest: compounds 2 and 1 (each within the scatter of the next); then compound 3.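

In this assay the thiophene's point of attachment next to the ring nitrogen registers, since thiophen-2-yl in place of thiophen-3-yl, with the same atoms joined differently, gives a 2.7-fold higher number from compound 2 to compound 3 (0.44 log units; beyond the scatter). With thiophen-2-yl held, 4-chlorophenyl in place of 2-chlorophenyl gives a 2.3-fold higher number from compound 1 to compound 3 (0.36 log units; beyond the scatter) and so shows that the chlorine's position on the phenyl also registers. Nothing available accounts for either step.

Open, going by these compounds, is whether the thiophene step carries over when 2-chlorophenyl is present. Also open, on these data alone, is how a plain phenyl or a pyridin-3-yl group would read in the thiophene's place.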